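A few compounds are considered here, and "the series" means these few. Any claim that something is new, unique, unknown or untested is made for them only; others in the source may bear on it.

Three measured compounds share one core and differ only in the group set on a double-bonded chain carbon bound to a double-bonded ring carbon. Compound 1 `CC(C)CN1C(=O)/C(=C/c2ccc(Cl)cc2)S/C1=N\c1ccccc1` carries a 4-chlorophenyl there, compound 2 `CC(C)CN1C(=O)/C(=C/c2ccc(N(C)C)cc2)S/C1=N\c1ccccc1` a 4-(dimethylamino)phenyl, and compound 3 `Cc1ccsc1/C=C1\S/C(=N\c2ccccc2)N(CC(C)C)C1=O` a 3-methylthiophen-2-yl. In a physicochemical assay for lipophilicity, measured as octanol-water partition (a lower number here means a more polar compound, a higher number a more lipophilic compound), compound 1 gives 5.98, compound 2 gives 5.49, and compound 3 gives 5.81. Compound 2 stands lowest of the three: a number 0.32 log units higher from compound 2 to compound 3 (beyond the scatter), and a number 0.49 log units lower from compound 1 to compound 2 (beyond the scatter). The third step, a number 0.17 log units lower from compound 1 to compound 3 (within the scatter), is small.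

Compound 4 `COc1cc(/C=C2\S/C(=N\c3ccccc3)N(CC(C)C)C2=O)ccc1O` has not yet been measured. It differs from compound 2 in one place:

4-hydroxy-3-methoxyphenyl in place of 4-(dimethylamino)phenyl on a double-bonded chain carbon bound to a double-bonded ring carbon

Within the data shown here, two measured steps bear on this, both exchanging the group at the same place: a number 0.49 log units lower from compound 1 to compound 2 (beyond the scatter) and a number 0.32 log units higher from compound 2 to compound 3 (beyond the scatter). Each was modest in this assay. The entering group brings one hydrogen-bond donor and two hydrogen-bond acceptors where the leaving group had no donor and one acceptor, so a downward step beyond the scatter, somewhat larger than either of those two, is expected. Compound 4 is therefore expected to give 4.8, with a range from 4.3 to 5.3. The expected step is a number 0.69 log units lower from compound 2 to compound 4 (beyond the scatter).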

Compound 4, partition coefficient: 4.92
Estimate against measurement, compound 4: 0.12 log units below; low and high end bracket the measured number.
By their numbers in this assay, from the lowest: compound 4; then compound 2; then compounds 3 and 1 (each within the scatter of the next).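

Among these compounds, at this place, on a double-bonded chain carbon bound to a double-bonded ring carbon, 4-hydroxy-3-methoxyphenyl takes this assay lower than any of the three earlier groups: a number 0.57 log units lower from compound 2 to compound 4 (beyond the scatter), a number 0.89 log units lower from compound 3 to compound 4 (beyond the scatter), and a number 1.06 log units lower from compound 1 to compound 4 (beyond the scatter), the last being the only large step in the set. The exchange with 4-(dimethylamino)phenyl leaves the heavy-atom count and the six-membered aromatic ring of carbon only unchanged, so this step appears between groups of equal heavy-atom count, with oxygen in place of nitrogen and with a hydrogen-bond donor entering. Nothing here identifies what lies behind this step.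

The compounds shown leave open how the step divides between the two substituents of the entering group, which a phenyl carrying only the hydroxy group or only the methoxy group would help to separate. They also leave open whether a carboxylic acid or a primary amine at this place would extend the range further, and whether the same exchange would give a similar step on a core with a longer chain on its ring nitrogen.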